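This account rests on a few compounds, and the source may have more. Where it says the series, first, only, none or still open, it means among the compounds named here.

- compound 1 `CSc1ccc(C2=C(c3ccc(F)c(C)c3)C(=O)N3CCCC3C2)cc1` in a functional assay on U-251 cells (Homo sapiens) for cytotoxicity (on this read-out lower numbers stand for stronger inhibition of growth and higher numbers for weaker inhibition of growth), gives 200 nM
- compound 2 `CSc1ccc(C2=C(c3ccc(Br)cc3)C(=O)N3CCCC3C2)cc1` gives 7000 nM

Compound 2 has the higher of the two numbers in this assay and sits beyond the scatter from compound 1. Compound 3 `CSc1ccc(C2=C(c3ccc(SC)cc3)C(=O)N3CCCC3C2)cc1` differs from compound 2 by methylsulfanyl in place of bromo on an aromatic carbon with methylsulfanyl in place of bromo on an aromatic carbon. For the measured compounds named here, only one measured step bears on this change (a 35-fold higher number from compound 1 to compound 2 (1.54 log units; beyond the scatter)). That step is large and alters the same aryl group, but it has no methylsulfanyl replacement at this aromatic carbon. A smaller move toward a lower number is therefore expected (a 3.5-fold lower number from compound 2 to compound 3 (0.54 log units; beyond the scatter)). Compound 3 is estimated at 2000 nM (range 300 nM to 10000 nM).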

Compound 3, concentration for 50% growth inhibition: 5000 nM
Beside the measured number, compound 3's estimate is 2.5-fold (0.40 log units) below it; low and high end bracket the measured number.
By their numbers in this assay, from the lowest: compound 1; then compounds 3 and 2 (each within the scatter of the next).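

In this assay, methylsulfanyl in place of bromo on this aromatic carbon gives a 1.4-fold lower number from compound 2 to compound 3 (0.15 log units; within the scatter), so the two groups are not told apart here. The gap to the 4-fluoro-3-methylphenyl group recurs with a second group, at a 25-fold higher number from compound 1 to compound 3 (1.40 log units; beyond the scatter), so it does not belong to bromo alone. Nothing available explains this result.

Open, as far as these compounds go, is whether an amine or a carboxylic acid on this aromatic carbon would depart from bromo and methylsulfanyl. Also open is how the fluoro and the methyl of compound 1 each contribute, as the compounds shown carry them only together.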